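The source may report more compounds than this note shows. Statements on the series, on what has been measured and on what is new or still open speak of the compounds shown alone.

Measured so far in a functional assay on HeLa cells (Homo sapiens) for cytotoxicity, read by MTT assay, with a stated time of 72 h; on this read-out lower numbers stand for stronger inhibition and higher numbers for weaker inhibition: compound 1 `NS(=O)(=O)c1cc(-c2nnc(CN3CCN(Cc4ccccc4)CC3)o2)c(Cl)cc1SCc1ccccc1` gives 17000 nM; compound 2 `NS(=O)(=O)c1cc(-c2nnc(CN3CCC(Cc4ccccc4)CC3)o2)c(Cl)cc1SCc1ccccc1` gives 16000 nM; compound 3 `NS(=O)(=O)c1cc(-c2nnc(CN3CCN(c4ccccc4)CC3)o2)c(Cl)cc1SCc1ccccc1` gives 100000 nM.

Compound 3 stands highest of the three numbers, with compound 1 and compound 2 both lower by steps beyond the scatter. Going by the values given here, the only single-point step in the set, a 5.9-fold higher number from compound 1 to compound 3 (0.77 log units; beyond the scatter), concerns phenyl in place of benzyl on an amine nitrogen in a ring and does not bear on the change now in question.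

Compound 4 `NS(=O)(=O)c1cc(-c2nnc(CN3CCN(c4ccc(F)cc4)CC3)o2)c(Cl)cc1SCc1ccccc1` differs from compound 3 by fluoro in place of hydrogen on an aromatic carbon. Among the compounds with values here, no measured pair shows fluoro in place of hydrogen on an aromatic carbon, so the data give no size or direction for it; the expectation is no step beyond the scatter. For compound 4 the estimated value in this assay is 100000 nM, with a range of 40000 nM to 250000 nM. The step this estimate implies, no change at the digits printed from compound 3 to compound 4 (within the scatter), is expected to stay within the scatter.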

Compound 4, half-maximal inhibitory concentration: 10000 nM
Beside the measured number, compound 4's estimate is 10-fold (1.00 log units) above it, and the stated range ends above it.
By their numbers in this assay, from the lowest: compounds 4, 2 and 1 (each within the scatter of the next); then compound 3.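

In this assay the phenyl ring of compound 3 proves sensitive to a single added atom: fluoro in place of hydrogen, para to a large group, gives a 10-fold lower number from compound 3 to compound 4 (1.00 log units; beyond the scatter) and so reverses the loss seen with plain phenyl. With 4-fluorophenyl in place of benzyl, a 1.7-fold lower number from compound 1 to compound 4 (0.23 log units; within the scatter) stays within the scatter. Nothing shown here accounts for the effect of fluoro.

Whether this step is specific to fluoro stays open, since chloro, methoxy or an amine on the same carbon are not among the compounds shown. Also open, from the compounds shown here alone, is whether fluoro would act likewise on the benzyl group of compound 1.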